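Swapping trifluoromethyl for dimethylamino on a weak growth inhibitor

The source may hold more compounds than are shown below. What is called first, only, known or untested is meant among the compounds shown, and "the series" means these compounds.

compound 1 `Cc1ccc2[nH]c(-c3ccc(-c4ccc(-c5cccc(Cl)c5)cc4)cc3)nc2c1` gives 2800 nM
compound 2 `COc1cc(-c2ccc(-c3ccc(-c4nc5cc(C)ccc5[nH]4)cc3)cc2)cc(OC)c1OC` gives 190 nM
compound 3 `FC(F)(F)c1ccc(-c2ccc(-c3ccc(-c4nc5ccccc5[nH]4)cc3)cc2)cc1` gives 100000 nM

In a functional assay on A2780 cells (Homo sapiens) for inhibition, read by sulforhodamine B assay (a lower number here means a stronger inhibitor of growth, a higher number a weaker inhibitor of growth), compound 3 (100000 nM) has the highest number of the three and is the weakest inhibitor, well beyond the scatter from both others. Compound 4 `CN(C)c1ccc(-c2ccc(-c3ccc(-c4nc5ccccc5[nH]4)cc3)cc2)cc1` differs from compound 3 in one place: dimethylamino in place of trifluoromethyl on an aromatic carbon, para to a large group (dimethylamino in place of trifluoromethyl on an aromatic carbon). Within the data shown here, no measured pair differs in just one place, so this step has no direct precedent. Compound 1 (2800 nM) and compound 2 (190 nM) each differ from compound 3 in more than one place, yet both sit far lower. A clear move toward stronger inhibition is therefore expected, though with wide uncertainty, and the estimated change is a 33-fold lower number from compound 3 to compound 4 (1.52 log units; beyond the scatter) in this measure. For compound 4 3000 nM is the expected value, with 300 nM to 40000 nM as the estimated range.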

Compound 4, concentration for 50% growth inhibition: 100000 nM
Compound 4: the middle estimate sits 33-fold (1.52 log units) below what was measured, and the stated range ends below it.
By their numbers in this assay, from the lowest: compound 2; then compound 1; then compounds 3 and 4 (each within the scatter of the next).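

In this assay, putting dimethylamino where trifluoromethyl stood on the aromatic carbon gives no change at the digits printed from compound 3 to compound 4 (within the scatter), so on this core the swap alone leaves growth inhibition unmoved. Dimethylamino brings a hydrogen-bond acceptor that trifluoromethyl lacks, yet the number stays where it was. No outside measurement bears on this result. Still open, on these data alone, is whether a carboxylic acid or a primary amine at this place would shift the number, and whether the same swap would also leave it unmoved on the core of compound 1 or compound 2.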